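Benzyl substituent changes on the shared indazole-free core series

The source may report more compounds than this note shows. Statements on the series, on what has been measured and on what is new or still open speak of the compounds shown alone.

Compound 1 `CCOC(=O)c1ccc(-c2nn(Cc3cccc(Cl)c3)c3ccccc23)cc1` sits at the lowest number of the three measured compounds in a functional assay on cells (Platelet, Homo sapiens) for inhibition (on this read-out higher numbers stand for weaker inhibition and lower numbers for stronger inhibition), where compound 1 gives 80 nM. Compound 2 `CCOC(=O)c1ccc(-c2nn(Cc3ccccc3F)c3ccccc23)cc1` gives 110 nM, and compound 3 `CCOC(=O)c1ccc(-c2nn(Cc3cccc(F)c3)c3ccccc23)cc1` gives 270 nM. The step of a 1.4-fold higher number from compound 1 to compound 2 (0.14 log units; within the scatter) stays within the scatter, whereas a 3.4-fold higher number from compound 1 to compound 3 (0.53 log units; beyond the scatter) and a 2.5-fold higher number from compound 2 to compound 3 (0.39 log units; beyond the scatter) are both modest losses beyond the scatter.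

Compound 4 `CCOC(=O)c1ccc(-c2nn(Cc3ccccc3OC)c3ccccc23)cc1` has not yet been measured in this assay. Its change from compound 1 is 2-methoxyphenyl in place of 3-chlorophenyl on a saturated chain carbon bound to an aromatic nitrogen. Two of the measured steps bear on it: the move of the substituent to the position seen in 2-fluorophenyl, which in a 1.4-fold higher number from compound 1 to compound 2 (0.14 log units; within the scatter) cost nothing beyond the scatter, and the exchange of chloro for a smaller group, which in a 3.4-fold higher number from compound 1 to compound 3 (0.53 log units; beyond the scatter) cost a modest amount. Methoxy in place of fluoro at the 2-position is untested here, so the expectation for compound 4 is a small weakening at most, with a 2.0-fold higher number from compound 1 to compound 4 (0.30 log units; within the scatter) expected to stay near the scatter boundary. Compound 4 is estimated at 160 nM, with a range from 60 nM to 450 nM.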

Compound 4, half-maximal inhibitory concentration: 470 nM
Compound 4: the middle estimate sits 2.9-fold (0.47 log units) below what was measured; the whole stated range lies below it.
By their numbers in this assay, from the lowest: compounds 1 and 2 (each within the scatter of the next); then compounds 3 and 4 (each within the scatter of the next).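

The exchange of 2-fluorophenyl for 2-methoxyphenyl is not neutral in this assay: methoxy in place of fluoro gives a 4.3-fold higher number from compound 2 to compound 4 (0.63 log units; beyond the scatter), so the tolerance seen for compound 2 does not extend to every group in that form of the ring. Among the compounds shown here, replacing 3-chlorophenyl gives a 5.9-fold higher number from compound 1 to compound 4 (0.77 log units; beyond the scatter), the largest step so far, while the comparison with 3-fluorophenyl gives a 1.7-fold higher number from compound 3 to compound 4 (0.24 log units; within the scatter), which leaves those two groups unresolved. Nothing available on the compounds accounts for the methoxy loss.

Chloro and methoxy each appear on only one form of the phenyl ring here, so the effect of the group cannot be separated from the effect of where it sits. As far as these compounds go, how an amine or a carboxylic acid on this ring would read out remains open, as does a longer chain in place of the benzyl link.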